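Adding a Hydroxy Group to Compound 3

A few compounds are considered here, and "the series" means these few. Any claim that something is new, unique, unknown or untested is made for them only; others in the source may bear on it.

In an ADME assay on cells (Hepatocyte, Mus musculus) for metabolic stability, with a stated time of 30 min (a lower number here means that less of the compound is left, a higher number that more of the compound is left), compound 1 (`O=C(OC1CCC(CN2CCN(c3cc(=O)c4cc(C(F)(F)F)cc([N+](=O)[O-])c4s3)CC2)CC1)c1ccccc1`) gives 68.1%, compound 2 (`O=C(NC1CCC(CN2CCN(c3cc(=O)c4cc(C(F)(F)F)cc([N+](=O)[O-])c4s3)CC2)CC1)c1ccccc1`) gives 90.6% and compound 3 (`O=c1cc(N2CCN(CC3CCCCC3)CC2)sc2c([N+](=O)[O-])cc(C(F)(F)F)cc12`) gives 80.6%. Compound 3 therefore sits level with compound 2 and clear of compound 1.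

Compound 4 (`O=c1cc(N2CCN(CC3CCC(O)CC3)CC2)sc2c([N+](=O)[O-])cc(C(F)(F)F)cc12`) has hydroxy in place of hydrogen on a saturated ring carbon. Three measured steps change that same carbon. The first is a number 12.5 percentage points higher from compound 1 to compound 3 (beyond the scatter), the second a number 10 percentage points lower from compound 2 to compound 3 (within the scatter) and the third a number 22.5 percentage points higher from compound 1 to compound 2 (beyond the scatter). Within the data shown here, no measured compound carries hydroxy, so these steps offer only indirect guidance. Compound 2 shows that a large benzamido group there leaves the number within the scatter of compound 3, with a number 10 percentage points lower from compound 2 to compound 3 (within the scatter). Compound 1, at 68.1%, shows that a modest drop remains possible. No step beyond the scatter is expected in this assay, and the estimated step is a number 2.6 percentage points lower from compound 3 to compound 4 (within the scatter). The expected value for compound 4 is 78%, with an estimated range from 62% to 93%.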

Compound 4, percent of the compound remaining in the Hepatocyte assay: 51.2%
The estimate for compound 4 lay 26.8 percentage points above the measured number; measured number below the stated range.
By their numbers in the Hepatocyte assay, from the lowest: compound 4; then compound 1; then compounds 3 and 2 (each within the scatter of the next).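

Among these compounds, in the Hepatocyte assay, this carbon proves far less forgiving than the earlier compounds suggested, and the smallest change yet made there carries a clear cost: a number 29.4 percentage points lower from compound 3 to compound 4 (beyond the scatter), a number 39.4 percentage points lower from compound 2 to compound 4 (beyond the scatter) and a number 16.9 percentage points lower from compound 1 to compound 4 (beyond the scatter). Among these four compounds the number does not follow the size of the group on that carbon, as hydroxy lies under benzoyloxy, benzamido and plain hydrogen alike. In a physicochemical assay for solubility, read by HPLC, with a stated time of 20 min (a lower number here means a less soluble compound, a higher number a more soluble compound), the same change comes with an at least 83-fold higher number from compound 3 to compound 4 (1.91 log units; beyond the scatter). In the physicochemical assay compound 3 gives < 0.1 ug/mL and this is a limit of the assay, not a number. In the physicochemical assay compound 4 gives 8.3 ug/mL as a measured number. The step thus starts from a limit of the assay on compound 3 and not from a number: the limit of < 0.1 ug/mL in the physicochemical assay, at which 1 of the 2 values shown sits.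

The compounds shown leave open whether methoxy, an amine or a carboxylic acid on that carbon would raise the number in the physicochemical assay as hydroxy does, without the step seen in the Hepatocyte assay. They also leave open what becomes of compound 4 in the cells.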